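Branching the ethyl amide of compound 3

The source may hold more compounds than are shown below. What is called first, only, known or untested is meant among the compounds shown, and "the series" means these compounds.

In a functional assay on HCT-116 cells (Homo sapiens) for antiproliferative activity, read by sulforhodamine B assay, with a stated time of 4 days (on this read-out higher numbers stand for weaker inhibition of growth and lower numbers for stronger inhibition of growth), compound 1 (`CCOc1cc(-c2nc(SCC(=O)NC3CC3)nc3[nH]cc(C#N)c23)c(Cl)cc1OC`) gives 20 nM, compound 3 (`CCNC(=O)CSc1nc(-c2cc(OCC)c(OC)cc2Cl)c2c(C#N)c[nH]c2n1`) gives 40 nM and compound 2 (`COc1cc(Cl)c(-c2nc(SCC(=O)NC(C)C)nc3[nH]cc(C#N)c23)cc1O`) gives 238 nM. Compound 3 holds the second highest of these three numbers, but only compound 2 is separated from it beyond the scatter.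

Compound 4 (`CCOc1cc(-c2nc(SCC(=O)NC(C)C)nc3[nH]cc(C#N)c23)c(Cl)cc1OC`) differs from compound 3 in one place: methyl in place of hydrogen on a saturated chain carbon bound to an amide-type nitrogen and a saturated chain carbon. This is methyl in place of hydrogen on a saturated chain carbon bound to an amide-type nitrogen and a saturated chain carbon, so ethylcarbamoyl becomes isopropylcarbamoyl.

Within the data shown here, the only measured single-place step on this amide nitrogen is a 2.0-fold higher number from compound 1 to compound 3 (0.30 log units; within the scatter), with ethyl in place of cyclopropyl. Among the measured compounds shown here, that one step is a thin basis, and no measured step shows the addition of this methyl directly. For the measured compounds named here, no single-place step connects compound 2 to the other compounds, so its number does not size the change. On this limited evidence, no shift beyond the scatter is expected in this assay. The estimate corresponds to an expected 1.1-fold lower number from compound 3 to compound 4 (0.06 log units; within the scatter). Compound 4 is estimated at 35 nM, with an expected range of 15 nM to 85 nM.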

Compound 4, concentration for 50% growth inhibition: 65 nM
Compound 4: the middle estimate sits 1.9-fold (0.27 log units) below what was measured; measured number inside the range.
By their numbers in this assay, from the lowest: compounds 1, 3 and 4 (each within the scatter of the next, the first and the last beyond it); then compound 2.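

In this assay, among these compounds, the first direct reading of this methyl is a 1.6-fold higher number from compound 3 to compound 4 (0.21 log units; within the scatter) and so stays inside the scatter, while the comparison with the cyclopropyl amide gives a 3.3-fold higher number from compound 1 to compound 4 (0.51 log units; beyond the scatter) and is the first modest step beyond the scatter at this amide-type nitrogen, which shows that the group there is not fully interchangeable even though neither ethyl step on its own exceeds the scatter. Among the compounds shown here, the isopropylcarbamoyl series also gains its first single-place link at the other varied site, where a 3.7-fold lower number from compound 2 to compound 4 (0.56 log units; beyond the scatter) comes with ethyl in place of hydrogen on an oxygen on an aromatic ring, a modest step beyond the scatter that sizes this change for the first time. No independent measurement is available to explain either step.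

As far as these compounds go, whether a tert-butyl group, a longer chain or a terminal amine on the amide-type nitrogen would remain within the scatter of compound 3 stays open. Also open, from the compounds shown here alone, is whether the step at the ring oxygen holds with the ethyl or cyclopropyl amide, or with a methyl or propyl ether at that oxygen.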